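Replacing 2,4-dimethoxyphenyl in compound 3 with 4-chlorophenyl

The source may report more compounds than this note shows. Statements on the series, on what has been measured and on what is new or still open speak of the compounds shown alone.

- compound 1 `c1ccc(C(c2c[nH]c3ccccc23)c2c[nH]c3ccccc23)cc1` gives 40000 nM 
- compound 2 `Oc1cccc(C(c2c[nH]c3ccc(Br)cc23)c2c[nH]c3ccc(Br)cc23)c1` gives 8000 nM 
- compound 3 `COc1ccc(C(c2c[nH]c3ccc(Br)cc23)c2c[nH]c3ccc(Br)cc23)c(OC)c1` gives 100000 nM 

In a functional assay on A549 cells (Homo sapiens) for inhibition, read by MTT assay, with a stated time of 48 h (on this read-out higher numbers stand for weaker inhibition and lower numbers for stronger inhibition), compound 3 gives 100000 nM as the highest number of the three. Compound 4 `Clc1ccc(C(c2c[nH]c3ccc(Br)cc23)c2c[nH]c3ccc(Br)cc23)cc1` keeps the core of compound 3 and differs in one place: 4-chlorophenyl in place of 2,4-dimethoxyphenyl on a saturated chain carbon bound to two aromatic carbons with 4-chlorophenyl in place of 2,4-dimethoxyphenyl on a saturated chain carbon bound to two aromatic carbons. Within the data shown here, only one measured step touches that place. That step, a 13-fold higher number from compound 2 to compound 3 (1.10 log units; beyond the scatter), was large and shows that the group there can move the number a long way. Among the measured compounds shown here, it starts from 3-hydroxyphenyl, however, and no measured compound with this core carries 4-chlorophenyl. Compound 1 at 40000 nM and compound 2 at 8000 nM both lie lower than compound 3, so a lower number is expected for compound 4, though by less than the measured step. The expected change in this assay is a 3.3-fold lower number from compound 3 to compound 4 (0.52 log units; beyond the scatter) by this estimate. For compound 4 the estimated value is 30000 nM, expected to fall between 10000 nM and 90000 nM in most measurements.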

Compound 4, half-maximal inhibitory concentration: 8500 nM
Estimate against measurement, compound 4: 3.5-fold (0.55 log units) above; the whole stated range lies above it.
By their numbers in this assay, from the lowest: compounds 2 and 4 (each within the scatter of the next); then compound 1; then compound 3.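

In this assay the move to 4-chlorophenyl brings a 12-fold lower number from compound 3 to compound 4 (1.07 log units; beyond the scatter) and so shows that a substituted phenyl at this place need not leave the number as high as 2,4-dimethoxyphenyl does. Set against 3-hydroxyphenyl, the same group gives a 1.1-fold higher number from compound 2 to compound 4 (0.03 log units; within the scatter) and the two cannot be told apart here, so among these compounds a hydrogen-bond donor on this phenyl is not needed to reach that level, as 4-chlorophenyl has 0 hydrogen-bond donors. Nothing shown here explains why these groups differ in this way.

From the compounds shown here alone, it remains open whether an aminophenyl, a carboxyphenyl or a fluorophenyl at this place would reach the level shared by compound 2 and compound 4 or pass it. The compounds shown also leave open what chlorine itself contributes, as no unsubstituted phenyl stands on the core of compound 4.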